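Dimethylamino to Cyano: Expected Shift in Effective Concentration

The compounds below may be only part of what the source reports. "The series", "measured", "known", "first", "only" and "open" are said of these compounds alone.

Compound 3 `COC(=O)C1=C(C)N=C(C)/C(=C(\O)OC)C1c1cccc(N(C)C)c1` gives the lowest number of the three measured in a functional assay (muscle tissue) with Cavia porcellus as the target (a higher number here means that more compound is needed for the effect, a lower number that less compound is needed), at 891 nM. Compound 2 `COC(=O)C1=C(C)N=C(C)/C(=C(\O)OC)C1c1cccc(OC(=O)c2ccccc2)c1` gives 6310 nM, and compound 1 `COC(=O)C1=C(C)N=C(C)/C(=C(\O)OC)C1c1ccccc1N` gives 39800 nM. Compound 4 `COC(=O)C1=C(C)N=C(C)/C(=C(\O)OC)C1c1cccc(C#N)c1` differs from compound 3 by cyano in place of dimethylamino on an aromatic carbon. Among the measured compounds shown here, no measured step exchanges dimethylamino for cyano; the only step at this aromatic carbon is a 7.1-fold lower number from compound 2 to compound 3 (0.85 log units; beyond the scatter), which shows that a change of group at this place can move the number well beyond the scatter. Because compound 3 gives 891 nM with dimethylamino present, compound 4, which lacks it, is expected to give a higher number, a step of a 3.4-fold higher number from compound 3 to compound 4 (0.53 log units; beyond the scatter). Compound 4 is estimated at 3000 nM, within 800 nM to 12000 nM.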

Compound 4, half-maximal effective concentration: 34.7 nM
Compound 4: the middle estimate sits 86-fold (1.94 log units) above what was measured; the whole stated range lies above it.
By their numbers in this assay, from the lowest: compound 4; then compound 3; then compound 2; then compound 1.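

In this assay, cyano in place of dimethylamino on this aromatic carbon is a large step (a 26-fold lower number from compound 3 to compound 4 (1.41 log units; beyond the scatter)), so the dimethylamino of compound 3 is not needed for a low number here. Cyano in place of benzoyloxy at the same carbon (a 180-fold lower number from compound 2 to compound 4 (2.26 log units; beyond the scatter)) and 3-cyanophenyl in place of 2-aminophenyl (a 1100-fold lower number from compound 1 to compound 4 (3.06 log units; beyond the scatter)) are larger still, widening the span this place can cover. No measurement at hand explains these steps. As far as these compounds go, whether a nitro group or a carboxylic acid on this carbon would match cyano remains open, as does how cyano behaves on another carbon of the ring.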